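Methoxy placement on the aryl ether: acid dissociation notes

The compounds below may be only part of what the source reports. "The series", "measured", "known", "first", "only" and "open" are said of these compounds alone.

Compound 1 `COc1ccc(Oc2ccc3c(NCCCNCc4cc(F)ccc4OC)ccnc3c2)cc1` gives 9.28 in a physicochemical assay for acid dissociation. Compound 2 `c1ccc(Oc2ccc3c(NCCCNCc4ccco4)ccnc3c2)cc1` gives 9.28, so compound 1 stands level with compound 2 at the digits shown, the two together the lowest of the three numbers. Within the data shown here, compound 3 `CC(C)CCc1ccc2c(NCCCNCc3ccco3)ccnc2c1` gives 9.47; the only measured step, a number 0.19 log units higher from compound 2 to compound 3 (within the scatter), stays within the scatter. Compound 4 `COc1cccc(Oc2ccc3c(NCCCNCc4cc(F)ccc4OC)ccnc3c2)c1` differs from compound 1 by 3-methoxyphenyl in place of 4-methoxyphenyl on an oxygen on an aromatic ring; cut one bond further out, the same difference reads 4-methoxyphenoxy to 3-methoxyphenoxy. Among the measured compounds shown here, no measured pair alters the group on this oxygen, and the one step elsewhere on the shared core moved nothing beyond the scatter. Expected, therefore, is no change at the digits printed from compound 1 to compound 4 (within the scatter), no change beyond the scatter. Compound 4 is expected to give 9.28, within 8.95 to 9.6.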

Compound 4, acid dissociation constant: 9.28
The estimate for compound 4 equals the measured number at the digits printed; measured number inside the range.
By their numbers in this assay, from the lowest: compounds 1, 2, 4 and 3 (each within the scatter of the next).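

In this assay, among these compounds, 3-methoxyphenyl in place of 4-methoxyphenyl on an oxygen on an aromatic ring gives no change at the digits printed from compound 1 to compound 4 (within the scatter) and so provides the first measured pair that alters the group on this oxygen. Among the compounds shown here, the reading covers only this exchange between two methoxyphenyl groups, with the rest of the structure held constant. No accompanying measurement accounts for this result.

Still open, on these data alone, is whether a carboxylic acid, an amine or a longer alkyl chain in place of the methoxy group would leave the number in this assay within the scatter.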